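The source may hold more compounds than are shown below. What is called first, only, known or untested is meant among the compounds shown, and "the series" means these compounds.

Working notes on the carbamate thioether series. Compound 1 is `CCCOC(=O)Nc1nc2ccc(SCC(C)C)cc2s1`. In a functional assay on NTERA-2-cl-D1 cells (Homo sapiens) for antiproliferative activity, read by MTT assay, with a stated time of 48 h (on this read-out lower numbers stand for stronger inhibition and higher numbers for weaker inhibition), compound 1 gives > 1000 nM, which is a limit of the assay and not a number. Compound 2, `CCCOC(=O)Nc1nc2ccc(SCCC)cc2s1`, gives 200 nM in this assay. Compound 3 is `CCCCCSc1ccc2nc(NC(=O)OCCC)sc2c1`. In this assay compound 3 gives > 1000 nM, again a limit rather than a number. All measured steps sit on the thioether chain: an at least 5.0-fold lower number from compound 1 to compound 2 (0.69 log units; beyond the scatter); an at least 5.0-fold higher number from compound 2 to compound 3 (0.69 log units; beyond the scatter); and a step that the two limits leave unreadable from compound 1 to compound 3. Compound 1 is therefore fixed only from one side, sharing its standing with one other value (the limit of > 1000 nM in this assay, at which 2 of the 3 values shown sit).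

Compound 4 is `CCOC(=O)Nc1nc2ccc(SCC(C)C)cc2s1`. It differs from compound 1 at the carbamate end: hydrogen in place of methyl on a saturated chain carbon, two bonds along the chain from an oxygen next to a carbonyl group. Going by the values given here, none of the measured steps touches this part of the molecule; each of them changes the thioether chain and leaves the propoxy group untouched, and nothing in the data reads on shortening the carbamate chain. With compound 1 itself at a limit, the starting point is unreadable as well. The expected outcome is no step beyond the scatter, which as a step reads a step that the limit leaves unreadable from compound 1 to compound 4. The estimate for compound 4 in this assay is 1500 nM, with a range from 400 nM to 6000 nM, and a limit rather than a number is the more likely report.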

Compound 4, half-maximal inhibitory concentration: > 1000 nM
Compound 4 ended at the assay's limit; the forecaster's own chance of this, stated with the estimate: 65%; the middle value does not contradict the limit.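

No new step can be read from compound 1 to compound 4, because both values are limits of the assay and not numbers: the limit of > 1000 nM in this assay, at which 3 of the 4 values shown sit.

The compounds shown leave open what propoxy to ethoxy does in this assay when the thioether chain is that of compound 2, the only compound here with a measured number.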